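The source may report more compounds than this note shows. Statements on the series, on what has been measured and on what is new or still open speak of the compounds shown alone.

In a functional assay on MIA PaCa-2 cells (Homo sapiens) for inhibition, read by MTT assay, with a stated time of 7 days (on this read-out higher numbers stand for weaker inhibition and lower numbers for stronger inhibition), compound 2 `CCN(CC)S(=O)(=O)c1ccc(S(=O)(=O)N2CCC[C@@H](C(=O)N3CCN(c4nc(C(C)C)no4)CC3)C2)cc1` gives 50 nM, and compound 1 `CC(C)c1noc(N2CCN(C(=O)[C@@H]3CCCN(S(=O)(=O)c4ccc(S(=O)(=O)C5CCC5)cc4)C3)CC2)n1` gives 70 nM, the two numbers lying within the usual scatter of each other. Compound 3 `CC(C)c1noc(N2CCN(C(=O)[C@@H]3CCCN(S(=O)(=O)c4ccc(S(=O)(=O)NC5CCC5)cc4)C3)CC2)n1` differs from compound 2 by cyclobutylamino in place of diethylamino on a sulfonyl sulfur. Among the measured compounds shown here, one measured step bears on this position: a 1.4-fold lower number from compound 1 to compound 2 (0.15 log units; within the scatter), a small move for a change of group on the same sulfonyl sulfur. The step expected here is therefore a 1.2-fold higher number from compound 2 to compound 3 (0.08 log units; within the scatter), nothing beyond the scatter. Compound 3 is estimated to give 60 nM, with a range from 25 nM to 150 nM.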

Compound 3, half-maximal inhibitory concentration: 600 nM
Estimate against measurement, compound 3: 10-fold (1.00 log units) below, and the stated range ends below it.
By their numbers in this assay, from the lowest: compounds 2 and 1 (each within the scatter of the next); then compound 3.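

On this sulfonyl sulfur, the choice of group matters far more than compound 1 and compound 2 alone suggested: this assay shows a 12-fold higher number from compound 2 to compound 3 (1.08 log units; beyond the scatter) and an 8.6-fold higher number from compound 1 to compound 3 (0.93 log units; beyond the scatter). Cyclobutylamino stands apart from both earlier groups, although it shares its ring with cyclobutyl and its heavy-atom count with diethylamino, and it adds a hydrogen-bond donor. Nothing measured here explains this weaker inhibition. The compounds shown leave open whether the ring or the hydrogen on the nitrogen accounts for the step, and how an ethylamino or a pyrrolidinyl group would fare.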